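Ethyl Extension in a Series Stuck at the Assay Limit

A few compounds are considered here, and "the series" means these few. Any claim that something is new, unique, unknown or untested is made for them only; others in the source may bear on it.

Compound 1 `Cc1ncn2c(O)nncc12`: > 48000 nM
Compound 2 `CCCc1ncn2c(O)nncc12`: > 48000 nM
Compound 3 `CCCc1nc(C)c2c(C)nnc(SC)n12`: > 48000 nM

In a functional assay for inhibition, with Homo sapiens as the target (on this read-out higher numbers stand for weaker inhibition and lower numbers for stronger inhibition), compound 1 gives only a limit, > 48000 nM. Compound 2 likewise gives only a limit in this assay, > 48000 nM. For compound 3 this assay also returns only a limit, > 48000 nM. All three therefore rest at the limit of > 48000 nM in this assay, at which 3 of the 3 values shown sit. The change from compound 1 to compound 2 is ethyl in place of hydrogen on a saturated chain carbon bound to an aromatic carbon, and the step that the two limits leave unreadable from compound 1 to compound 2. Compound 4 `CCCc1nnc(SC)n2c(CCC)nc(C)c12` is not yet measured; it differs from compound 3 by ethyl in place of hydrogen on a saturated chain carbon bound to an aromatic carbon, the same change at the same place. The difference between the cores of compound 1 and compound 3 is not broken down here. Because every measured value sits at the limit of > 48000 nM in this assay, at which 3 of the 3 values shown sit, the expected step that the limit leaves unreadable from compound 3 to compound 4 cannot be anchored to a readable number. Compound 4 is therefore expected to give about 60000 nM in this assay, most likely again only as a limit.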

Compound 4, half-maximal inhibitory concentration: > 48000 nM
Compound 4 gave a limit, no number (the forecaster's own chance of this, stated with the estimate: 85%); the middle value is on the limit's open side.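

No step can be read from compound 3 to compound 4, as both give only a limit: the limit of > 48000 nM in this assay, at which 4 of the 4 values shown sit.

The compounds shown leave open whether ethyl in place of hydrogen changes inhibition at all in this assay.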